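What a new side group may do to compound 2

A few compounds are considered here, and "the series" means these few. Any claim that something is new, unique, unknown or untested is made for them only; others in the source may bear on it.

Measured in an ADME assay on microsomes from liver (Mus musculus) for metabolic stability, read by mass spectrometry, with a stated time of 40 min, tested at 1 uM; a lower number here means that less of the compound is left, a higher number that more of the compound is left:
- compound 1 `COc1cc(N2CCN(C(=O)N3CCC(O)C3)CC2)ccc1Nc1nc(NC2CCCCC2)c2nc[nH]c2n1`: 47%
- compound 2 `COc1cc(N2CCC(C(=O)N3CCOCC3)CC2)ccc1Nc1nc(NC2CCCCC2)c2nc[nH]c2n1`: 70%

Of these two, compound 2 stands higher, and its gap to compound 1 lies beyond the usual scatter. Compound 3 `COc1cc(N2CCC(CC(=O)N3CCC(N(C)C)C3)CC2)ccc1Nc1nc(NC2CCCCC2)c2nc[nH]c2n1` differs from compound 2 on a saturated ring carbon, where ((3-(dimethylamino)pyrrolidin-1-yl)carbonyl)methyl takes the place of (morpholin-4-yl)carbonyl: ((3-(dimethylamino)pyrrolidin-1-yl)carbonyl)methyl in place of (morpholin-4-yl)carbonyl on a saturated ring carbon. Among the compounds with values here, no measured pair differs in one place only, so the guidance here is thin. In this assay a drop beyond the scatter is expected, the estimated step being a number 22 percentage points lower from compound 2 to compound 3 (beyond the scatter). The estimate for compound 3 is 48%, with an expected range from 22% to 74%.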

Compound 3, percent of the compound remaining: 48%
Estimate against measurement, compound 3: no gap at the digits printed; the range from low to high includes it.
By their numbers in this assay, from the lowest: compounds 1 and 3 (each within the scatter of the next); then compound 2.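

In this assay, placing ((3-(dimethylamino)pyrrolidin-1-yl)carbonyl)methyl in place of (morpholin-4-yl)carbonyl on this saturated ring carbon gives a number 22 percentage points lower from compound 2 to compound 3 (beyond the scatter), so the group at this position matters for this read-out. The change alters the ring and the link to the carbonyl together, so neither can be credited alone. No measurement at hand gives a reason for the drop.

Open, as far as these compounds go, is how (morpholin-4-yl)carbonylmethyl, which has the longer link but keeps the morpholine ring, would behave here. So is a pyrrolidin-1-ylcarbonyl group without the dimethylamino group.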